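Adding a methyl to compound 3's phenyl ring

This account rests on a few compounds, and the source may have more. Where it says the series, first, only, none or still open, it means among the compounds named here.

Of the compounds shown here, three sharing one core have been tested in a functional assay on HeLa cells (Homo sapiens) for cytotoxicity, read by MTT assay, with a stated time of 48 h; a higher number here means a weaker inhibitor, a lower number a stronger inhibitor. Compound 1 `CCOC(=O)c1c(-c2cc3ccccc3oc2=O)nn(-c2ccccc2)c1C(=O)OCC` gives 100000 nM. Compound 2 `CCOC(=O)c1c(-c2cc3ccccc3oc2=O)nn(-c2cccc(C)c2)c1C(=O)OCC`, which carries a methyl group on the phenyl ring, gives 245000 nM. Compound 3 `CCOC(=O)c1c(-c2cc3cc(OC)ccc3oc2=O)nn(-c2ccccc2)c1C(=O)OCC`, which carries a methoxy group on the other ring instead, gives 145000 nM. Compound 3 sits close to both of its neighbours: the gap to compound 1 and the gap to compound 2 each lie within the usual scatter, so no real difference between them can be claimed.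

Compound 4 `CCOC(=O)c1c(-c2cc3cc(OC)ccc3oc2=O)nn(-c2cccc(C)c2)c1C(=O)OCC` is still to be measured. It differs from compound 3 by methyl in place of hydrogen on an aromatic carbon. The same change has been seen once before in this set: going from compound 1 to compound 2 gave a 2.5-fold higher number from compound 1 to compound 2 (0.39 log units; beyond the scatter). The change from compound 1 to compound 3, by contrast, gave a 1.5-fold higher number from compound 1 to compound 3 (0.16 log units; within the scatter), which does not bear on the methyl step. For the measured compounds named here, with only one precedent, the expectation for compound 4 is a weakening of the same modest size, roughly a 2.5-fold higher number from compound 3 to compound 4 (0.39 log units; beyond the scatter) in this assay. Compound 4 is therefore estimated at 360000 nM, with a likely range from 150000 nM to 850000 nM.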

Compound 4, half-maximal inhibitory concentration: 155000 nM
The estimate for compound 4 lay 2.3-fold (0.37 log units) above the measured number, within the range that was stated.
By their numbers in this assay, from the lowest: compounds 1, 3, 4 and 2 (each within the scatter of the next, the first and the last beyond it).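

On the core that carries the methoxy group, the change from phenyl to 3-methylphenyl in this assay gives a 1.1-fold higher number from compound 3 to compound 4 (0.03 log units; within the scatter), so the methyl step that stood beyond the scatter on the core of compound 1 is not repeated here. This does not show that the methoxy group alters what the methyl does, since the two readings of the methyl step agree within the scatter: the same change on two cores in this assay, a 2.5-fold higher number (0.39 log units; beyond the scatter) from compound 1 to compound 2 and a 1.1-fold higher number (0.03 log units; within the scatter) from compound 3 to compound 4, 2.3-fold (0.36 log units) apart, within the scatter of two such steps The methoxy change, now read a second time on the core that carries the methyl, gives a 1.6-fold lower number from compound 2 to compound 4 (0.20 log units; within the scatter), and this reading also agrees with the earlier one within the scatter: the same change on two cores in this assay, a 1.5-fold higher number (0.16 log units; within the scatter) from compound 1 to compound 3 and a 1.6-fold lower number (0.20 log units; within the scatter) from compound 2 to compound 4, 2.3-fold (0.36 log units) apart, within the scatter of two such steps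

Going by these compounds, it remains open whether the step from compound 1 to compound 2 is a lasting effect of the methyl or a reading that happens to lie just beyond the scatter, and a further pair with the same change on another core would help to settle that. On these data alone, whether a different group in the same place on the phenyl ring, such as an amine, a carboxylic acid or a longer chain, would move the number further from that of compound 1 at 100000 nM also remains open.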